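What Losing an Ethoxy Group Might Cost in Potency

A few compounds are considered here, and "the series" means these few. Any claim that something is new, unique, unknown or untested is made for them only; others in the source may bear on it.

Compound 2 `CCOc1ccc2nc(NC(=S)Nc3ccccc3)sc2c1` was tested in a functional assay on THP-1 cells (Homo sapiens) for cytotoxicity, read by MTT assay, with a stated time of 48 h (a lower number here means a stronger inhibitor, a higher number a weaker inhibitor), where compound 2 gives 43800 nM. Compound 3 `CCOc1ccc2nc(Nc3nc4ccc(F)cc4s3)sc2c1` in this assay gives 39000 nM, a value within the scatter of that of compound 2, so the two cannot be ordered. Compound 1 `Fc1ccc2nc(Nc3nc4ccccc4s3)sc2c1` in this assay reaches only the limit > 50000 nM; > 50000 nM (2 entries), not a number. Of the two numbered values, compound 2 holds the higher one. Compound 4 `S=C(Nc1ccccc1)Nc1nc2ccccc2s1` is not yet measured; it differs from compound 2 in one place: hydrogen in place of ethoxy on an aromatic carbon. Among the compounds with values here, no measured pair shows this change, so its size is unknown. Because compound 2 already sits at 43800 nM, the expected step of a 1.1-fold higher number from compound 2 to compound 4 (0.06 log units; within the scatter) is small, toward a weaker inhibitor if anything. Compound 4 is therefore estimated at 50000 nM, ranging from 20000 nM to 125000 nM.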

Compound 4, half-maximal inhibitory concentration: 36500 nM
Beside the measured number, compound 4's estimate is 1.4-fold (0.14 log units) above it, within the range that was stated.
By their numbers in this assay, from the lowest: compounds 4, 3 and 2 (each within the scatter of the next).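

Replacing ethoxy with hydrogen on this aromatic carbon now has a measured size in this assay, where the step is a 1.2-fold lower number from compound 2 to compound 4 (0.08 log units; within the scatter) and the two compounds cannot be ordered. Losing the ethoxy group therefore carries no potency cost that this assay can resolve in this pair, which no earlier pair could show. Nothing available explains this result.

Going by these compounds, whether an amine, a carboxylic acid or a longer alkoxy chain on this carbon would give a step beyond the scatter remains open. So does whether any such group would give a stronger inhibitor.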